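Chain extension on the amide of compound 2

The compounds below may be only part of what the source reports. "The series", "measured", "known", "first", "only" and "open" are said of these compounds alone.

Three compounds of the series have numbers in an assay on mitochondria (strain Sprague-Dawley) for inhibition of Amine oxidase [flavin-containing] B (Rattus norvegicus), read by fluorescence and Amplex Red, with stated times of 30 min and 45 min; on this read-out lower numbers stand for stronger inhibition and higher numbers for weaker inhibition. Compound 1, `O=C(CCCc1ccccc1)Nc1nc2ccsc2c(=O)s1`, gives 298 nM in this assay. Compound 2, `O=C(CCc1ccccc1)Nc1nc2ccccc2c(=O)s1`, gives 42.7 nM. Compound 3, `COc1cccc(/C=C/C(=O)Nc2nc3ccccc3c(=O)s2)c1`, gives 281 nM. Compound 2 stands lowest of the three; compound 3 lies nearest with a number beyond the scatter above it, and compound 1 lies furthest, also beyond the scatter. Compound 1 and compound 2 differ in more than one place, so their two values are read only as what they show.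

Compound 4, `O=C(CCCc1ccccc1)Nc1nc2ccccc2c(=O)s1`, is not yet measured. Relative to compound 2 the change is benzyl in place of phenyl on a saturated chain carbon, two bonds along the chain from a carbonyl carbon, a chain longer by one saturated carbon with the shared core of compound 2 kept. For the measured compounds named here, no measured pair in the set isolates this change, and the only other compound with the longer chain, compound 1, carries a different core, so its value is not a direct guide.

The expectation for compound 4 in this assay is a small loss relative to compound 2, a 2.1-fold higher number from compound 2 to compound 4 (0.32 log units; beyond the scatter), possibly within the scatter. Compound 4 is estimated at 90 nM, with a range from 30 nM to 300 nM.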

Compound 4, half-maximal inhibitory concentration: 186 nM
Compound 4: the middle estimate sits 2.1-fold (0.32 log units) below what was measured, and the stated range covers the measured number.
By their numbers in this assay, from the lowest: compound 2; then compounds 4, 3 and 1 (each within the scatter of the next).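

In this assay, for the compounds shown here, the first matched pair at this position shows that benzyl in place of phenyl on a saturated chain carbon, two bonds along the chain from a carbonyl carbon, is not a neutral change on the shared core: the step is a 4.4-fold higher number from compound 2 to compound 4 (0.64 log units; beyond the scatter) and lies beyond the scatter. The earlier compounds shown here could not show this, since compound 1 carries the longer chain on a different core and compound 3 differs from compound 2 in more than one place, so the length of the chain can now be read on its own as a modest loss from the phenyl-ended chain of compound 2. No measurement shown here explains the step, which remains a single pair on one core and one read-out.

Going by these compounds, whether the loss continues with a still longer chain, or whether a shorter chain ending in phenyl holds or improves the number, stays open with only these two lengths on the shared core. Also open, on these data alone, is whether an ether oxygen within the chain, or a pyridine ring in place of the terminal phenyl, would be tolerated at this position on the core of compound 2.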